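Swapping Cyano for Trifluoromethoxy on a Urea Series

A few compounds are considered here, and "the series" means these few. Any claim that something is new, unique, unknown or untested is made for them only; others in the source may bear on it.

Measured so far:
compound 1, `CC1(C)CCOc2ccc(NC(=S)Nc3ccc(OC(F)(F)F)cc3)cc21`: 16%
compound 2, `CC1(C)CC(C)(C)c2cc(NC(=O)Nc3ccc(C#N)cc3)ccc2O1`: 93%
compound 3, `CC1(C)CCOc2ccc(NC(=O)Nc3ccc(OC(F)(F)F)cc3)cc21`: 36%

Three ureas and thioureas have been tested in a functional assay on A2780 cells (Homo sapiens) for inhibition, with a stated time of 72 h, tested at 10 uM; a lower number here means less inhibition of growth, a higher number more inhibition of growth at the concentration tested. Compound 2 stands highest of the three numbers; compound 3, its nearest neighbour, lies well below it, and compound 1 lies furthest down, both gaps beyond the usual scatter. Compound 1 and compound 3 share the smaller core and the trifluoromethoxy group, and both give modest growth inhibition.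

The new compound 4, `CC1(C)CC(C)(C)c2cc(NC(=O)Nc3ccc(OC(F)(F)F)cc3)ccc2O1`, keeps the core and the urea of compound 2 but carries a different group on the far ring: trifluoromethoxy in place of cyano on an aromatic carbon. Going by the values given here, no measured pair shows this change on its own, so its size is not known. Because compound 3 gives 36% with the same trifluoromethoxy group, though on another core, a downward step of moderate size, beyond the scatter, is expected. Compound 4 is therefore estimated at 70%, within a range from 40% to 92%. The step expected from compound 2 to compound 4 in this assay is a number 23 percentage points lower from compound 2 to compound 4 (beyond the scatter).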

Compound 4, percent growth inhibition at one concentration: 91.5%
Estimate against measurement, compound 4: 21.5 percentage points below; measured number inside the range.
By their numbers in this assay, from the lowest: compound 1; then compound 3; then compounds 4 and 2 (each within the scatter of the next).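

In this assay, placing trifluoromethoxy in place of cyano on an aromatic carbon, para to a large group, leaves growth inhibition unchanged within the scatter (a number 1.5 percentage points lower from compound 2 to compound 4 (within the scatter)). On the core and urea of compound 2, this position therefore accepts either group, even though trifluoromethoxy has 5 heavy atoms and cyano has 2, so trifluoromethoxy does not by itself go with modest growth inhibition. No measurement at hand explains why the two groups give such similar results.

The compounds shown leave open how an amine or a carboxylic acid would behave at this position, and whether a thiourea would keep this level of inhibition on the core of compound 2. No pair shown isolates the effect of the core itself.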